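A few compounds are considered here, and "the series" means these few. Any claim that something is new, unique, unknown or untested is made for them only; others in the source may bear on it.

Measured so far:
Compound 1, `CC(=O)Nc1cc(NC(=O)Nc2cccc(Oc3ccccc3)c2)ccc1C`, in a functional assay on A375P cells (Homo sapiens) for antiproliferative activity; on this read-out lower numbers stand for stronger inhibition and higher numbers for weaker inhibition: > 30000 nM.
Compound 2, `Cc1ccc(NC(=O)Nc2cccc(Oc3ccccc3)c2)cc1NC(=O)c1ccccc1`: > 30000 nM.
Compound 3, `CC(=O)Nc1cc(NC(=O)c2ccc3c(c2)OCCO3)ccc1C`: 12900 nM.

The value of compound 1 in this assay is a limit of the assay, not a number. The same holds for compound 2, whose value is also a limit. Compound 3 alone gives a number. Compound 2 differs from compound 1 by phenyl in place of methyl on a carbonyl carbon; the step that the two limits leave unreadable from compound 1 to compound 2 cannot be read because both compounds sit at the limit of > 30000 nM in this assay, at which 2 of the 3 values shown sit. How the core of compound 3 differs from the core of compound 1 is not broken down here.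

Compound 4, `Cc1ccc(NC(=O)c2ccc3c(c2)OCCO3)cc1NC(=O)c1ccccc1`, is not yet measured. It differs from compound 3 by phenyl in place of methyl on a carbonyl carbon, the same change as before, made at the same place. What that change did from compound 1 to compound 2 stays hidden, so the expectation for compound 4 rests on compound 3 at 12900 nM as the only readable anchor. Compound 4 is expected near 15000 nM, with a range from 4000 nM to 40000 nM. Among the measured compounds shown here, the estimated step is a 1.2-fold higher number from compound 3 to compound 4 (0.07 log units; within the scatter), kept small because the one readable anchor is compound 3 at 12900 nM.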

Compound 4, half-maximal inhibitory concentration: > 30000 nM
Compound 4: no number, only a limit (the forecaster's own chance of this, stated with the estimate: 45%); middle value at least 2.0-fold (0.30 log units) away from the limit.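

In this assay, putting phenyl in place of methyl on a carbonyl carbon of the core of compound 3 gives an at least 2.3-fold higher number from compound 3 to compound 4 (0.36 log units; beyond the scatter), so on this core the change moves the read-out towards weaker inhibition. Compound 4 gives > 30000 nM, which is a limit of the assay and not a number, so only the lowest possible size of this step is known. The same change on the core of compound 1 cannot be read, as compound 1 and compound 2 both stand at a limit, so this result does not show that the change acts alike on both cores, and the series leaves little room to compare steps: the limit of > 30000 nM in this assay, at which 3 of the 4 values shown sit.

The compounds shown leave open whether a different group on that carbonyl carbon, such as an amine or a longer chain, would give a readable number on either core. Going by these compounds, it also stays open whether a carboxylic acid on the added phenyl would bring compound 4 to a readable number.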